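A few compounds are considered here, and "the series" means these few. Any claim that something is new, unique, unknown or untested is made for them only; others in the source may bear on it.

Working notes on the series. Going by the values given here, in an ADME assay on cells (spleen, Mus musculus, strain C57BL/6) for inhibition, read by flow cytometry and propidium iodide staining, with a stated time of 24 h, at 37 degrees C (a lower number here means that less compound is needed, a higher number that more compound is needed for the effect), compound 1 `O=C(Cn1cc(CCCCO)nn1)NCc1ccccc1` gives 1700 uM and is the only compound so far with a number. Compound 2 `O=C(Cn1cc(C(=O)O)nn1)NCc1ccccc1` is reported only as "non-toxic" (no number reported) with no figure to compare. Compound 3 `NCc1cn(CC(=O)NCc2ccccc2)nn1` reads > 2000 uM, which is a limit and not a number. That leaves compound 3 at the limit of > 2000 uM in this assay, at which 1 of the 3 values shown sits, so its true position is open.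

The next structure is compound 4 `Nc1cccc(-c2cn(CC(=O)NCc3ccccc3)nn2)c1`, which carries 3-aminophenyl in place of aminomethyl on an aromatic carbon.

Among the compounds with values here, one measured step touches this same carbon of the core: an at least 1.1-fold higher number from compound 1 to compound 3 (0.07 log units; that floor lies within the scatter). Within the data shown here, it says little, and no measured step brings a ring onto that carbon, so the size of the coming change rests on thin ground. Compound 1 shows that a different group there can still give a readable number, 1700 uM in this assay, so a modest move towards a lower number is expected. A result within the scatter of the limit for compound 3 would not surprise.

The expected move is an at least 1.6-fold lower number from compound 3 to compound 4 (0.22 log units; that floor lies within the scatter) in this estimate. For compound 4 the estimated value is 1200 uM, with an expected range from 400 uM to 3000 uM.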

Compound 4, concentration for half-maximal effect: 800 uM
Compound 4: the middle estimate sits 1.5-fold (0.18 log units) above what was measured, and the stated range covers the measured number.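

Going by these compounds alone, on this aromatic carbon of the core, 3-aminophenyl in place of 4-hydroxybutyl gives the first step at this position that lies beyond the scatter in this assay (a 2.1-fold lower number from compound 1 to compound 4 (0.33 log units; beyond the scatter)). 3-aminophenyl in place of aminomethyl points the same way (an at least 2.5-fold lower number from compound 3 to compound 4 (0.39 log units; beyond the scatter)), so both readable steps that bring a six-membered aromatic ring of carbon only onto this carbon lead to a lower number, and the larger group still gives a readable value. The second step gives only a floor and not a size, since compound 3 stands at a limit and not at a number: the limit of > 2000 uM in this assay, at which 1 of the 4 values shown sits.

The compounds shown do not separate the part played by the ring from that of its amine, and a plain phenyl group with no amine on this carbon would be the direct comparison with the 3-aminophenyl group. From the compounds shown here alone, how far a shorter or longer alkyl amine would move the number also stays open, and steps to compound 2 cannot be read, as it carries no figure in this assay.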